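The compounds below may be only part of what the source reports. "The series", "measured", "known", "first", "only" and "open" are said of these compounds alone.

Compound 1 `CCCCCCCCCO[C@@H]1[C@@H](N)[C@@H](OCC(O)CO)O[C@H](CN)[C@H]1OCCCCCCCCC` is an aminoglycoside-derived amphiphile whose two nonyl chains sit on the shared core. In a toxicity assay on the whole organism (J774 cells) for cytotoxicity, with Mus musculus as the target, read by MTT assay, with a stated time of 24 h, tested at 30 uM (on this read-out higher numbers stand for a weaker effect at the one concentration tested and lower numbers for a stronger effect), compound 1 gives 8.8%, the lowest of the three numbers shown. Compound 2 `NC[C@H]1O[C@H](O[C@H]2[C@H](O)[C@@H](O)[C@H](N)C[C@@H]2N)[C@H](N)[C@@H](OCCCc2ccc3ccccc3c2)[C@@H]1OCCCc1ccc2ccccc2c1` gives 66.9% in this assay, and compound 3 `NC[C@H]1O[C@H](O[C@H]2[C@H](OCCCc3ccc4ccccc4c3)[C@@H](O)[C@H](N)C[C@@H]2N)[C@H](N)[C@@H](OCCCc2ccc3ccccc3c2)[C@@H]1O` gives 89.5%; both lie beyond the scatter above compound 1. Compound 4 `CCCCCCCCCO[C@@H]1[C@@H](N)[C@@H](OC[C@@H](O)CN)O[C@H](CN)[C@H]1OCCCCCCCCC` has not yet been measured in this assay. It differs from compound 1 in one place: 2-amino-1-hydroxyethyl in place of 1,2-dihydroxyethyl on a saturated chain carbon bound to an oxygen on a saturated carbon. Among the compounds with values here, no step between measured compounds of this kind is known, so the expectation rests on compound 1 alone. Because compound 1 already gives 8.8%, the step from compound 1 to compound 4 is expected to stay within the scatter, a number 1.2 percentage points higher from compound 1 to compound 4 (within the scatter). Compound 4 is therefore estimated at 10%, within a range of 3% to 30%.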

Compound 4, a percentage reported as activity, at one concentration (the size of the read-out at that concentration, not a potency): 7.2%
The estimate for compound 4 lay 2.8 percentage points above the measured number; measured number inside the range.
By their numbers in this assay, from the lowest: compounds 4 and 1 (each within the scatter of the next); then compound 2; then compound 3.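

In this assay, 2-amino-1-hydroxyethyl in place of 1,2-dihydroxyethyl on a saturated chain carbon bound to an oxygen on a saturated carbon gives a number 1.6 percentage points lower from compound 1 to compound 4 (within the scatter). The earlier compounds shown here held no step of any kind; this one shows that, with the nonyl chains kept, the reading at this position does not separate on this exchange. Nothing shown here explains the result. Open, from the compounds shown here alone, is whether a carboxylic acid or a longer chain at this position would shift the reading. Also open, going by these compounds, is whether the other configuration of the new stereocentre would read the same.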